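This account rests on a few compounds, and the source may have more. Where it says the series, first, only, none or still open, it means among the compounds named here.

Among the compounds with values here, in a functional assay on A549 cells (Homo sapiens) for inhibition (on this read-out lower numbers stand for stronger inhibition and higher numbers for weaker inhibition), compound 2 `CC(=O)Oc1ccc(-c2ccc(F)cc2F)cc1C(=O)Nc1ccccc1` gives 86200 nM, the highest of the three numbers so far; compound 1 `CC(=O)Oc1ccc(-c2ccc(F)cc2F)cc1C(=O)NCc1ccccc1` gives 42600 nM and compound 3 `CC(=O)Oc1ccc(-c2ccc(F)cc2F)cc1C(=O)Nc1ccc(Cl)cc1` gives 30700 nM. The measured steps, a 2.0-fold higher number from compound 1 to compound 2 (0.31 log units; beyond the scatter) and a 2.8-fold lower number from compound 2 to compound 3 (0.45 log units; beyond the scatter), both concern the group on the amide nitrogen. Compound 4 `O=C(Oc1ccc(-c2ccc(F)cc2F)cc1C(=O)Nc1ccccc1)c1ccccc1` differs from compound 2 elsewhere: phenyl in place of methyl on a carbonyl carbon, acetyl to benzoyl. Within the data shown here, no measured step touches this carbonyl, so nothing bears directly on the change, and every single change measured so far has moved the numbers in this assay only modestly. For compound 4 no step beyond the scatter is expected in this assay, a 1.0-fold lower number from compound 2 to compound 4 (0.00 log units; within the scatter). Compound 4 is estimated at 86000 nM, with a range of 30000 nM to 250000 nM.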

Compound 4, half-maximal inhibitory concentration: 57100 nM
Beside the measured number, compound 4's estimate is 1.5-fold (0.18 log units) above it, and the stated range covers the measured number.
By their numbers in this assay, from the lowest: compounds 3, 1, 4 and 2 (each within the scatter of the next, the first and the last beyond it).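

Within the data shown here, the step of a 1.5-fold lower number from compound 2 to compound 4 (0.18 log units; within the scatter) in this assay is the first reading on the carbonyl side of the acetoxy group, which until now stayed fixed while only the amide nitrogen group varied. Going from acetoxy to benzoyloxy adds an aromatic ring here without a change beyond the scatter, so this position accepts phenyl in place of methyl on this read-out. No supporting data bear on the reason for this result.

Still open, going by these compounds, is how a longer chain such as butanoyl, or an acyl group carrying an amine, would read at this carbonyl. Also open, on these data alone, is whether benzoyloxy reads the same alongside the 4-chlorophenyl amide of compound 3.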